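This account rests on a few compounds, and the source may have more. Where it says the series, first, only, none or still open, it means among the compounds named here.

Measured so far:
- compound 1, `O=C(Nc1cccc(-n2cc(-c3ccncc3)c(-c3cc(O)cc(Cl)c3)n2)c1)Nc1ccc(Cl)c(C(F)(F)F)c1`, -80%
- compound 2, `COc1cc(Cl)cc(-c2nn(-c3cccc(NC(=O)Nc4ccc(Cl)c(C(F)(F)F)c4)c3)cc2-c2ccncc2)c1`, -82%
- compound 3, `COc1cc(Cl)cc(-c2nn(-c3cccc(NC(=O)Nc4ccc(Cl)c(Cl)c4)c3)cc2-c2ccncc2)c1`, -21%

In a functional assay on SF-295 cells (Homo sapiens) for inhibition, read by sulforhodamine B assay, with a stated time of 48 h, tested at 100 uM (a higher number here means a weaker effect of the compound at the concentration tested, a lower number a stronger effect), compound 2 gives the lowest of the three numbers. Compound 1 is close to it, a number 2 percentage points lower from compound 1 to compound 2 (within the scatter), whereas compound 3 lies far from it, a number 61 percentage points higher from compound 2 to compound 3 (beyond the scatter).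

Compound 4, `COc1cc(Cl)cc(-c2nn(-c3cccc(NC(=O)Nc4cccc(C(F)(F)F)c4)c3)cc2-c2ccncc2)c1`, is not yet measured. It differs from compound 2 in one place: hydrogen in place of chloro on an aromatic carbon.

Among the compounds with values here, no measured step removes the chloro itself. The step from compound 2 to compound 3, a number 61 percentage points higher from compound 2 to compound 3 (beyond the scatter), shows that changing a group on the same ring can move the number a great deal in this assay, so the ring with the trifluoromethyl group matters. Taking the chloro away is therefore expected to raise the number, though probably by less than that step did.

Compound 4 is estimated at -45%, with a range from -80% to 0%. This means an expected step of a number 37 percentage points higher from compound 2 to compound 4 (beyond the scatter).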

Compound 4, a percentage reported as activity, at one concentration (the size of the read-out at that concentration, not a potency): -53%
Beside the measured number, compound 4's estimate is 8 percentage points above it; measured number inside the range.
By their numbers in this assay, from the lowest: compounds 2 and 1 (each within the scatter of the next); then compound 4; then compound 3.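

In this assay, the chloro ortho to a trifluoromethyl group counts on its own: replacing it with hydrogen gives a number 29 percentage points higher from compound 2 to compound 4 (beyond the scatter), so the trifluoromethyl group alone does not account for the low number of compound 2. The trifluoromethyl group without the chloro still keeps part of the effect, since exchanging 3,4-dichlorophenyl for 3-(trifluoromethyl)phenyl gives a number 32 percentage points lower from compound 3 to compound 4 (beyond the scatter), and among these three compounds the ring carrying both groups gives the lowest number. Nothing measured here accounts for either step.

Still open, going by these compounds, is whether a bromo, a methyl or an amine in place of the chloro would keep the number of compound 2 or lose the effect as hydrogen does. Also open, on these data alone, is whether the same loss would appear with the hydroxyl group of compound 1 in place of the methoxy.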